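The compounds below may be only part of what the source reports. "The series", "measured", "known", "first", "only" and "open" are said of these compounds alone.

Measured compounds:
Compound 1 `Cc1noc(C)c1S(=O)(=O)N1CCC(N2CCC(C)CC2)CC1` — > 5000 nM
Compound 2 `Cc1cc(C)c(S(=O)(=O)N2CCC(N3CCC(CCO)CC3)CC2)c(C)c1` — 19 nM
Compound 3 `Cc1cc(C)c(S(=O)(=O)N2CCC(c3ccccc3)CC2)c(C)c1` — > 5000 nM

In a functional assay on DLD-1 cells (Homo sapiens) for antiproliferative activity, read by CellTiter-Glo, with a stated time of 72 h (on this read-out higher numbers stand for weaker inhibition and lower numbers for stronger inhibition), compound 1 gives only a limit, > 5000 nM, not a number; this is the limit of > 5000 nM in this assay, at which 2 of the 3 values shown sit. Compound 2 gives 19 nM in this assay. Among the measured compounds shown here, the single measured step, an at least 260-fold higher number from compound 2 to compound 3 (2.42 log units; beyond the scatter), changes a different part of the shared core and so does not bear on the change studied here. The unmeasured compound 4 `CC1CCN(C2CCN(S(=O)(=O)c3cccc(Cl)c3)CC2)CC1` differs from compound 1 by 3-chlorophenyl in place of 3,5-dimethyl-1,2-oxazol-4-yl on a sulfonyl sulfur. For the measured compounds named here, no measured pair shows the effect of exchanging the group on the sulfonyl sulfur alone, so the direction is open. Compound 4 is therefore expected near the limit, with an estimated 1500 nM (between 100 nM and 5000 nM), a step of an at least 3.3-fold lower number from compound 1 to compound 4 (0.52 log units; beyond the scatter).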

Compound 4, half-maximal inhibitory concentration: > 5000 nM
Compound 4 ended at the assay's limit; the forecaster's own chance of this, stated with the estimate: 45%; at least 3.3-fold (0.52 log units) between middle value and limit.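

Compound 1 and compound 4 both end at a limit rather than a number, so no step between them can be read: the limit of > 5000 nM in this assay, at which 3 of the 4 values shown sit.

Going by these compounds, whether 3-chlorophenyl in place of 3,5-dimethyl-1,2-oxazol-4-yl on a sulfonyl sulfur changes the activity at all stays open.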